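Acetyl removal at the primary hydroxyl of compound 3

The source may hold more compounds than are shown below. What is called first, only, known or untested is meant among the compounds shown, and "the series" means these compounds.

Three compounds of the shared core carry a number in a functional assay on T47D cells (Homo sapiens) for antiproliferative activity, read by sulforhodamine B assay, with a stated time of 48 h; on this read-out lower numbers stand for stronger inhibition of growth and higher numbers for weaker inhibition of growth. Compound 1 `COc1cc(C2=NOC(CO[C@@H]3O[C@H](CSc4ncn[nH]4)[C@H]4OC5(CCCC5)O[C@@H]34)C2)cc(OC)c1OC` gives 55000 nM. Compound 2 `Nc1nnc(SC[C@H]2O[C@@H](OCc3noc(-c4ccc(Cl)cc4)n3)[C@@H]3OC4(CCCC4)O[C@@H]32)s1` gives 18000 nM. Compound 3 `CC(=O)OC[C@H]1O[C@@H](OCc2noc(-c3ccc([N+](=O)[O-])cc3)n2)[C@@H]2OC3(CCCC3)O[C@@H]21` gives 52000 nM, the second highest of the three numbers; its nearest neighbour is compound 1, within the scatter, and its furthest is compound 2, whose lower number lies beyond the scatter.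

Compound 4 `O=[N+]([O-])c1ccc(-c2nc(CO[C@@H]3O[C@H](CO)[C@H]4OC5(CCCC5)O[C@@H]34)no2)cc1` is not yet measured. It differs from compound 3 in one place: hydrogen in place of acetyl on an oxygen on a saturated carbon. Going by the values given here, no pair of measured compounds is separated by this change alone, so its weight in this assay is unknown. The three measured compounds carry three different groups on that oxygen or on the adjoining carbon and all sit in the same weak region, which suggests the position tolerates variation without large swings.

The step from compound 3 to compound 4 is therefore expected to be small, most likely none beyond the scatter, a 1.2-fold higher number from compound 3 to compound 4 (0.06 log units; within the scatter). For compound 4 the estimate in this assay is 60000 nM, with a range from 25000 nM to 150000 nM.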

Compound 4, concentration for 50% growth inhibition: 50000 nM
Beside the measured number, compound 4's estimate is 1.2-fold (0.08 log units) above it; the measured number falls inside the stated range.
By their numbers in this assay, from the lowest: compound 2; then compounds 4, 3 and 1 (each within the scatter of the next).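

Hydrogen in place of acetyl on this oxygen gives a 1.0-fold lower number from compound 3 to compound 4 (0.02 log units; within the scatter) in this assay, the first reading of this change alone, since the earlier compounds differed from one another in more than one place. The two numbers cannot be told apart, so acetoxymethyl to hydroxymethyl, which removes three heavy atoms and a hydrogen-bond acceptor, has no visible effect on this read-out in this pair. No measurement at hand bears on why the pair reads alike.

From the compounds shown here alone, it remains open whether an amine, a carboxylic acid or a longer ester such as a benzoate at this position would also read alike. A single pair also leaves open whether hydrogen in place of acetyl gives the same result in compounds with other groups elsewhere on the shared core.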